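The compounds below may be only part of what the source reports. "The series", "measured", "known", "first", "only" and "open" are said of these compounds alone.

Of the compounds shown here, three from this series have been measured in a functional assay on A498 cells (Homo sapiens) for inhibition, read by sulforhodamine B assay, with a stated time of 48 h; a higher number here means a weaker inhibitor of growth, a lower number a stronger inhibitor of growth. Compound 1, with the structure `COc1cc(C)cc(-c2c(-c3ccnc(-c4ccc(C(C)=O)cc4)c3)cnn2CC#N)c1`, gives 2030 nM in this assay. Compound 2, `COc1cc(C)cc(-c2nn(CC#N)cc2-c2ccc(-c3cccc(C(C)=O)c3)nc2)c1`, gives 1080 nM, and compound 3, `Cc1cc(O)cc(-c2nn(CC#N)cc2-c2ccnc(-c3ccc(N(C)C)cc3)c2)c1`, gives 3030 nM. Compound 1 stands with the second highest number of the three, and both of its neighbours lie within the usual scatter of repeated measurements, so no ordering among the three can be claimed.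

Compound 4, `COc1cc(C)cc(-c2c(-c3ccnc(-c4ccc(N(C)C)cc4)c3)cnn2CC#N)c1`, is the next compound to be measured. It differs from compound 1 in one place: dimethylamino in place of acetyl on an aromatic carbon. Going by the values given here, no pair of measured compounds differs by exactly this change, so there is no measured step to lean on. Compound 3 also carries a dimethylamino group but differs from compound 1 elsewhere as well; its value and that of compound 1 sit within the scatter of each other. On that basis the step from compound 1 to compound 4 is expected to be a 1.2-fold higher number from compound 1 to compound 4 (0.07 log units; within the scatter), with no change beyond the scatter. Compound 4 is therefore expected to give about 2400 nM in this assay, within a range of 1000 nM to 6000 nM.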

Compound 4, concentration for 50% growth inhibition: 132 nM
For compound 4 the middle estimate is 18-fold (1.26 log units) above the measured one, outside the stated range (below it).
By their numbers in this assay, from the lowest: compound 4; then compounds 2, 1 and 3 (each within the scatter of the next, the first and the last beyond it).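

In this assay, putting 4-(dimethylamino)phenyl in place of 4-acetylphenyl gives a 15-fold lower number from compound 1 to compound 4 (1.19 log units; beyond the scatter) and is the first change in one place among the compounds shown. It shows that the group at this place on the six-membered carbon ring can strongly change the measured growth inhibition, even though acetyl and dimethylamino have the same number of heavy atoms and hydrogen-bond acceptors and no hydrogen-bond donors. No measurement shown here explains why the number moves so far.

The compounds shown leave open whether this result is specific to dimethylamino or would also appear with a primary amine or a morpholine ring at the same place. They also leave open whether the same swap would have a similar effect on a different core.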